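Pyrazolyl for phenyl on the benzamide: expected effect on MV4-11

The source may hold more compounds than are shown below. What is called first, only, known or untested is meant among the compounds shown, and "the series" means these compounds.

The series shares one core; compound 1 `CNC(=O)N1CCCc2ccc(NC(=O)c3ccc(-c4ccccc4)cc3)cc21` and compound 3 `CNC(=O)N1CCCc2ccc(NC(=O)c3cccc(-c4ccccc4)c3)cc21` are built from the same atoms joined differently, and the difference between the two cores is not broken down here. In a functional assay on MV4-11 cells (Homo sapiens) for antiproliferative activity, with a stated time of 6 days, tested at 6.25 uM (a higher number here means a stronger effect of the compound at the concentration tested, a lower number a weaker effect), compound 1 gives 74.3%, whereas compound 3 gives 1.39%.

Compound 2 `CNC(=O)N1CCCc2ccc(NC(=O)c3cccc(-c4ccn(C)n4)c3)cc21` arises from compound 3 through (1-methyl-1H-pyrazol-3-yl in place of phenyl on an aromatic carbon). This change produced a number 98.1 percentage points higher from compound 3 to compound 2 (beyond the scatter), so that compound 2 reaches 99.5% in this assay, the highest of the three measured numbers.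

Compound 4 `CNC(=O)N1CCCc2ccc(NC(=O)c3ccc(-c4ccn(C)n4)cc3)cc21` is not yet measured. It arises from compound 1 through (1-methyl-1H-pyrazol-3-yl in place of phenyl on an aromatic carbon). The two changes are of the same kind, but the surroundings differ: in compound 3 the replaced phenyl sits meta to a large group, in compound 1 it sits para to a large group.

For the measured compounds named here, for compound 4 in this assay a step of a number 18.7 percentage points higher from compound 1 to compound 4 (beyond the scatter) is expected, smaller than the one seen from compound 3 to compound 2, because compound 1 already gives 74.3% and leaves little room above it, while compound 3 started from near zero. Going by the values given here, the expectation rests on the single matched pair and on the high starting point of compound 1 only. Compound 4 is therefore estimated at 93%, with a plausible range from 76% to 100% in this assay.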

Compound 4, a percentage reported as inhibition, at one concentration (the size of the read-out at that concentration, not a potency): 97%
Estimate against measurement, compound 4: 4 percentage points below; the range from low to high includes it.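

In this assay the replacement of phenyl by 1-methyl-1H-pyrazol-3-yl also raises the read-out on the core of compound 1, with a number 22.7 percentage points higher from compound 1 to compound 4 (beyond the scatter). The direction of the change therefore carries over between these two cores, but the size of the step does not: the same change on two cores in this assay, a number 98.1 percentage points higher (beyond the scatter) from compound 3 to compound 2 and a number 22.7 percentage points higher (beyond the scatter) from compound 1 to compound 4, 75.4 percentage points apart, beyond the scatter of two such steps. These two matched pairs show neither why the steps differ nor how the change would behave on any other core, and as each read-out comes from one concentration, they give the size of the effect at that concentration and not a shift in potency.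

The compounds shown leave open whether the rise belongs to the 1-methyl-1H-pyrazol-3-yl group in particular or would also follow from another group on the same aromatic carbon, such as a pyridine ring, a morpholine or a carboxylic acid. On these data alone, it also remains open whether the methyl on the pyrazole matters, a question that the unsubstituted pyrazole or a longer chain such as ethyl in its place would address on both cores.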